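Arylsulfonamide variation on the shared core, compound 4 next

The compounds below may be only part of what the source reports. "The series", "measured", "known", "first", "only" and "open" are said of these compounds alone.

Compound 3 `CN(c1ccc2[nH]c(-c3n[nH]c4ccccc34)cc2n1)S(=O)(=O)c1ccc(Br)cc1` gives 9850 nM in a functional assay on HCT-116 cells (Homo sapiens) for antiproliferative activity, read by MTT assay, with a stated time of 72 h; a lower number here means a stronger inhibitor, a higher number a weaker inhibitor; among the three measured numbers it stands second highest, nearest compound 1 `CC(=O)N(C)c1ccc2[nH]c(-c3n[nH]c4ccccc34)cc2n1` with 14800 nM and furthest from compound 2 `CN(c1ccc2[nH]c(-c3n[nH]c4ccccc34)cc2n1)S(=O)(=O)c1ccc(Cl)cc1` with 5980 nM, both gaps within the scatter. Within the data shown here, the only step beyond the scatter is a 2.5-fold lower number from compound 1 to compound 2 (0.39 log units; beyond the scatter), while a 1.5-fold lower number from compound 1 to compound 3 (0.18 log units; within the scatter) and a 1.6-fold higher number from compound 2 to compound 3 (0.22 log units; within the scatter) stay within it.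

Compound 4 `COc1ccc(S(=O)(=O)N(C)c2ccc3[nH]c(-c4n[nH]c5ccccc45)cc3n2)c(OC)c1` differs from compound 3 by 2,4-dimethoxyphenyl in place of 4-bromophenyl on a sulfonyl sulfur. Among the measured compounds shown here, the one measured step that touches this aryl ring is a 1.6-fold higher number from compound 2 to compound 3 (0.22 log units; within the scatter), an exchange of one halogen for another that moved the number only within the scatter. For the measured compounds named here, no measured compound carries a methoxy group on that ring, so the two methoxy groups of compound 4 are untested here; the data give no ground for a direction. The acetyl-to-arylsulfonyl steps from compound 1 show the arylsulfonyl series sits in a narrow band, which is the best guide.

Compound 4 is therefore expected to show no step beyond the scatter, a 1.1-fold lower number from compound 3 to compound 4 (0.04 log units; within the scatter), with an estimate of 9000 nM and a range from 3000 nM to 30000 nM in this assay, the wide range reflecting the untested methoxy groups.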

Compound 4, half-maximal inhibitory concentration: 21800 nM
Compound 4: middle estimate off by 2.4-fold (0.38 log units), on the low side; low and high end bracket the measured number.
By their numbers in this assay, from the lowest: compounds 2, 3, 1 and 4 (each within the scatter of the next, the first and the last beyond it).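

In this assay the aryl group on the sulfonyl sulfur is not a silent position: 2,4-dimethoxyphenyl in place of 4-bromophenyl gives a modest step (a 2.2-fold higher number from compound 3 to compound 4 (0.35 log units; beyond the scatter)) and 2,4-dimethoxyphenyl in place of 4-chlorophenyl gives a larger one (a 3.6-fold higher number from compound 2 to compound 4 (0.56 log units; beyond the scatter)), whereas the exchange of one halogen for the other stayed within the scatter. Among these compounds, the closeness of compound 2 and compound 3 therefore does not extend to every aryl group at this place, and the first change of ring substituent type moves the number upward, towards a weaker inhibitor, from both halogen compounds. Nothing measured here accounts for this step.

The two methoxy groups enter together, so the compounds shown leave open whether a single methoxy group on that ring would produce the same step. Also open, from the compounds shown here alone, is how the series would respond at this sulfonyl sulfur to a ring bearing an amine or a carboxylic acid, or to a longer alkyl chain in place of the aryl ring.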